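Cytotoxicity of Bis-Chalcone Phenols on Human Kidney Cells

The source may report more compounds than this note shows. Statements on the series, on what has been measured and on what is new or still open speak of the compounds shown alone.

Compound 2 `Cc1cc(O)c(C(=O)/C=C/c2ccc(F)cc2)c(-c2ccccc2)c1C(=O)/C=C/c1ccc(F)cc1` has no single number in an ADME assay on HEK293 cells (Homo sapiens) for cytotoxicity, read by MTT assay, with a stated time of 24 h; on this read-out lower numbers stand for stronger inhibition and higher numbers for weaker inhibition; it is reported there only as "not active" (no number reported). Compound 1 `Cc1cc(O)c(C(=O)/C=C/c2ccccc2)c(-c2ccccc2)c1C(=O)/C=C/c1ccccc1` stands the same way, reported in this assay as "not active" (no number reported), also without a number. The only figure in this series comes from compound 3 `Cc1cc(O)c(C(=O)/C=C/c2ccccc2)c(-c2ccc(Br)cc2)c1C(=O)/C=C/c1ccccc1`, which in this assay gives 30000 nM. Compound 4 `Cc1cc(O)c(C(=O)/C=C/c2ccc(F)cc2)c(-c2ccc(OCc3ccccc3)cc2)c1C(=O)/C=C/c1ccc(F)cc1` differs from compound 2 by benzyloxy in place of hydrogen on an aromatic carbon. Within the data shown here, with no measured step of this kind to compare, the size of this change cannot be told from the data, and the expectation is a step no larger than the usual scatter of this assay. Compound 4 is therefore expected to remain weak in this assay, with an estimated value of 30000 nM, between 8000 nM and 100000 nM.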

Compound 4, half-maximal inhibitory concentration: 30000 nM
The estimate for compound 4 equals the measured number at the digits printed; the range from low to high includes it.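

Among these compounds, compound 2 has no number and compound 4 gives 30000 nM, so no step between them can be read. The compounds shown leave open how much benzyloxy in place of hydrogen changes cytotoxicity. No evidence here bears on this result.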